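A few compounds are considered here, and "the series" means these few. Any claim that something is new, unique, unknown or untested is made for them only; others in the source may bear on it.

Working notes on the series built on the shared core of compound 1 (`C=C(Br)C(=O)Nc1cccc(/C=C/C(=O)Nc2ccccc2)c1`), followed in a functional assay on HeLa cells (Homo sapiens) for inhibition, read by MTT assay, with a stated time of 72 h; on this read-out higher numbers stand for weaker inhibition and lower numbers for stronger inhibition. In this assay compound 1 gives 7300 nM, compound 2 (`C=C(Br)C(=O)Nc1cccc(/C=C/C(=O)Nc2ccc(F)cc2)c1`) gives 16800 nM and compound 3 (`C=C(Br)C(=O)Nc1cccc(/C=C/C(=O)Nc2ccc(OC(F)(F)F)cc2)c1`) gives 29000 nM. Compound 3 therefore sits level with compound 2 and clearly apart from compound 1: a 1.7-fold higher number from compound 2 to compound 3 (0.24 log units; within the scatter), whereas a 4.0-fold higher number from compound 1 to compound 3 (0.60 log units; beyond the scatter).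

The next analogue is compound 4 (`C=C(Br)C(=O)Nc1cccc(/C=C/C(=O)Nc2ccc(SC(F)(F)F)cc2)c1`), with (trifluoromethyl)sulfanyl in place of trifluoromethoxy on an aromatic carbon, para to a large group: (trifluoromethyl)sulfanyl in place of trifluoromethoxy on an aromatic carbon.

Replacing hydrogen at this place gave modest steps, a 2.3-fold higher number from compound 1 to compound 2 (0.36 log units; beyond the scatter) and a 4.0-fold higher number from compound 1 to compound 3 (0.60 log units; beyond the scatter). These bear on the change only indirectly, since compound 4 exchanges one substituent for another. For the measured compounds named here, the closest precedent is the only such exchange measured so far, a 1.7-fold higher number from compound 2 to compound 3 (0.24 log units; within the scatter). No step beyond the scatter is therefore expected in this assay, though a single precedent is thin support.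

The expected change is a 1.1-fold lower number from compound 3 to compound 4 (0.03 log units; within the scatter). The estimated value for compound 4 is 27000 nM, with an expected range of 12000 nM to 60000 nM.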

Compound 4, half-maximal inhibitory concentration: 19000 nM
Compound 4: the middle estimate sits 1.4-fold (0.15 log units) above what was measured, within the range that was stated.
By their numbers in this assay, from the lowest: compound 1; then compounds 2, 4 and 3 (each within the scatter of the next).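

In this assay, the exchange of trifluoromethoxy for (trifluoromethyl)sulfanyl at this position, a 1.5-fold lower number from compound 3 to compound 4 (0.18 log units; within the scatter), is a second exchange of one substituent for another that stays inside the scatter, and the fluoro comparison, a 1.1-fold higher number from compound 2 to compound 4 (0.05 log units; within the scatter), stays inside it as well. With a 2.6-fold higher number from compound 1 to compound 4 (0.42 log units; beyond the scatter), a third substituent now stands clearly apart from hydrogen, so across these four compounds the separation lies between hydrogen and the substituents, not among the substituents themselves. Nothing available explains the size of these steps.

Open, going by these compounds, is whether a substituent of another kind at this place, such as an amine, a carboxylic acid or a hydroxyl group, would stay level with these three. On these data alone, it is equally open whether any such group would come closer to compound 1 at 7300 nM.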